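Swapping a fluoro for a methyl on the aryl ring

The compounds below may be only part of what the source reports. "The series", "measured", "known", "first", "only" and "open" are said of these compounds alone.

Measured so far:
Compound 1, `O=C1CSC(c2cccc(F)c2)N1CCN1CCCCC1`: 92%
Compound 2, `O=C1CSC(c2ccc(F)cc2)N1CCN1CCCCC1`: 87%

Both compounds share one core and differ only in the fluorophenyl attached to a saturated ring carbon. In an ADME assay on Vero cells (Chlorocebus sabaeus) for cytotoxicity, read by neutral red uptake, tested at 98 ug/mL (on this read-out higher numbers stand for a weaker effect at the one concentration tested and lower numbers for a stronger effect), compound 1 gives 92%, and in this assay compound 2 gives 87%. Among the measured compounds shown here, only one step is available, a number 5 percentage points lower from compound 1 to compound 2 (within the scatter), so the two numbers cannot be told apart, and compound 2 stands alongside compound 1 with little sign of a strong effect at the concentration tested.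

Compound 3, `Cc1ccc(C2SCC(=O)N2CCN2CCCCC2)cc1`, has not yet been tested in this assay. It differs from compound 2 as follows: methyl in place of fluoro on an aromatic carbon. For the measured compounds named here, no measured step involves a methyl in place of a fluoro, so nothing here speaks directly to this change. Going by the values given here, the only step available, moving the fluoro around the ring, stayed within the scatter. On that thin basis, compound 3 is expected to sit close to compound 2, with a change of no change at the digits printed from compound 2 to compound 3 (within the scatter) that is not expected to exceed the scatter. The estimate for compound 3 is 87%, expected to fall between 72% and 98%.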

Compound 3, a percentage reported as activity, at one concentration (the size of the read-out at that concentration, not a potency): 100%
Compound 3: the middle estimate sits 13 percentage points below what was measured, outside the stated range (above it).
By their numbers in this assay, from the lowest: compounds 2, 1 and 3 (each within the scatter of the next, the first and the last beyond it).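

In this assay, among the compounds shown here, the step at this aromatic carbon, para to a large group, gives a number 13 percentage points higher from compound 2 to compound 3 (beyond the scatter) and is the first step to pass the scatter, which here means a modestly weaker effect at the one concentration tested. So exchanging fluoro for methyl, each a single heavy atom with no hydrogen-bond donors or acceptors, can move this read-out by a small but readable amount, which the shift of the fluoro around the ring did not do. The result still rests on a single pair, since the other comparison gives a number 8 percentage points higher from compound 1 to compound 3 (within the scatter) and so separates nothing, and no measurement at hand offers an explanation for the step.

What the compounds shown leave open is how far this place tolerates other groups, such as a methoxy, an amine or a longer chain like ethyl. On these data alone, it also remains open whether any group here could bring the number well down and so show a strong effect at this concentration.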